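Swapping Fluoro for Methyl on Two Inactive Compounds

A few compounds are considered here, and "the series" means these few. Any claim that something is new, unique, unknown or untested is made for them only; others in the source may bear on it.

Compound 1 `CC(C(=O)N1CCN(c2ccc(F)cc2)CC1)N1C(=O)CCC1=O` gives 0% in a functional assay on the whole organism (strain Swiss) with Mus musculus as the target, in the maximal electroshock model, with a stated time of 1 h, at a dose of 100 mg/kg by the intraperitoneal route; on this read-out lower numbers stand for a weaker effect and higher numbers for a stronger effect at the one dose given.
Compound 2 `CC(C(=O)N1CCN(c2cccc(F)c2)CC1)N1C(=O)CCC1=O` gives 0% in this assay.

Compound 2 stands level with compound 1 in this assay; the step of no change at the digits printed from compound 1 to compound 2 (within the scatter) shows no change at the digits measured. Compound 3 `Cc1cccc(N2CCN(C(=O)C(C)N3C(=O)CCC3=O)CC2)c1` is not yet measured and differs from compound 2 by methyl in place of fluoro on an aromatic carbon. Among the measured compounds shown here, no measured step replaces fluoro with methyl, so the only guide is a pair that both show no effect. The step of a number 5 percentage points higher from compound 2 to compound 3 (within the scatter) is therefore expected to be small, with no direction beyond the scatter. Compound 3 is estimated at 5%, ranging from 0% to 25%.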

Compound 3, a percentage reported as activity, at one dose (the size of the read-out at that dose, not a potency): 0%
Compound 3: the middle estimate sits 5 percentage points above what was measured; low and high end bracket the measured number.
By their numbers in this assay, from the lowest: compounds 1, 2 and 3 (each within the scatter of the next).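

Methyl in place of fluoro on this aromatic carbon leaves the read-out in this assay flat (no change at the digits printed from compound 2 to compound 3 (within the scatter)), and the wider change from 4-fluorophenyl to 3-methylphenyl does the same (no change at the digits printed from compound 1 to compound 3 (within the scatter)). So a carbon group at this place, like fluoro, gives no detectable effect at the one dose given. Nothing available explains this flat result.

As far as these compounds go, whether a methoxy group, an amine or a trifluoromethyl on this ring would give any effect stays open. So does the effect of changing the shared core itself.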